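Series notes: the step away from 4-pentylphenyl

The source may hold more compounds than are shown below. What is called first, only, known or untested is meant among the compounds shown, and "the series" means these compounds.

Of the compounds shown here, two have been read in a functional assay on HCT-116 cells (Homo sapiens) for antiproliferative activity, read by MTT assay, with a stated time of 72 h; a higher number here means a weaker inhibitor, a lower number a stronger inhibitor. Compound 1 `O=C1O/C(=C\Cn2cc(-c3cc(F)cc(F)c3)nn2)C(OCc2ccccc2)=C1OCc1ccccc1` gives only a limit, > 100000 nM. Going by the values given here, compound 2 `CCCCCc1ccc(-c2cn(C[C@H](O)[C@H]3OC(=O)C(OCc4ccccc4)=C3OCc3ccccc3)nn2)cc1` gives 13800 nM, the only true number so far, and it therefore serves as the sole numeric reference, with no measured step to calibrate against.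

Compound 3 `O=C1O[C@H]([C@@H](O)Cn2cc(CNS(=O)(=O)c3ccc(Cl)cc3)nn2)C(OCc2ccccc2)=C1OCc1ccccc1` keeps the shared core of compound 2 and changes one substituent: (((4-chlorophenyl)sulfonyl)amino)methyl in place of 4-pentylphenyl on an aromatic carbon. Here (((4-chlorophenyl)sulfonyl)amino)methyl stands in place of 4-pentylphenyl on an aromatic carbon of a five-membered aromatic ring with 3 nitrogen.

Among the compounds with values here, no measured pair shows what such an exchange does, so the expectation is loose. It rests on compound 2 at 13800 nM and on the size of the structural change. A moderate move toward weaker inhibition, somewhat beyond the scatter, is expected, and the estimated change is a 2.5-fold higher number from compound 2 to compound 3 (0.40 log units; beyond the scatter). For compound 3 the expected value in this assay is 35000 nM, with an estimated range of 9000 nM to 100000 nM.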

Compound 3, half-maximal inhibitory concentration: 8380 nM
Estimate against measurement, compound 3: 4.2-fold (0.62 log units) above; the whole stated range lies above it.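

Going by these compounds alone, the first readable exchange on this aromatic carbon of the five-membered aromatic ring with 3 nitrogen gives, in this assay, a 1.6-fold lower number from compound 2 to compound 3 (0.22 log units; within the scatter). Compound 2 and compound 3 therefore read alike, although 4-pentylphenyl, an all-carbon group with no hydrogen-bond donor or acceptor, has given way to (((4-chlorophenyl)sulfonyl)amino)methyl, which carries sulfur, nitrogen, oxygen and chlorine as well as a hydrogen-bond donor and acceptors; at this position, with this core, the two substituents cannot be told apart in this read-out. Compound 3 gives a true number, while compound 1 remains a limit of the assay rather than a number: the limit of > 100000 nM in this assay, at which 1 of the 3 values shown sits.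

Within the data shown here, the single step cannot show which part of either substituent matters, since the pentyl chain, the chlorine and the sulfonyl-amino link all differ together. A primary amine or a carboxylic acid on the same aromatic carbon, or a longer chain in place of pentyl, would show whether this position responds to its substituent at all.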